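Swapping a six-membered ring for a triazole at the carbonyl

This account rests on a few compounds, and the source may have more. Where it says the series, first, only, none or still open, it means among the compounds named here.

Measured so far:
- Compound 1, `O=C(C1CCN(C(=O)C(F)(F)F)CC1)N1N=CCC1c1ccccc1`, gives 4.9.
- Compound 2, `O=C(c1cn[nH]c1)N1CCC(C(=O)N2N=CCC2c2ccccc2)CC1`, gives 2.1.
- Compound 3, `O=C(c1cccnc1)N1CCC(C(=O)N2N=CCC2c2ccccc2)CC1`, gives 2.6.

These three numbers come from a physicochemical assay for lipophilicity, read by HPLC, measured as chromatographic lipophilicity, at pH 7.4; a lower number here means a more polar compound, a higher number a more lipophilic compound. Compound 3 stands second highest of the three: compound 1 is far higher, while compound 2 is the nearest neighbour and lies lower by a number 0.50 log units higher from compound 2 to compound 3 (beyond the scatter).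

Compound 4, `O=C(c1c[nH]nn1)N1CCC(C(=O)N2N=CCC2c2ccccc2)CC1`, has not yet been measured. It differs from compound 3 in one place: 1H-1,2,3-triazol-4-yl in place of pyridin-3-yl on a carbonyl carbon.

Going by the values given here, two measured steps bear on this. The step of a number 2.30 log units lower from compound 1 to compound 3 (beyond the scatter) shows how far this assay moves when an aromatic ring replaces trifluoromethyl on the carbonyl carbon. More directly, the step of a number 0.50 log units higher from compound 2 to compound 3 (beyond the scatter) compares a five-membered ring bearing one hydrogen-bond donor with the six-membered pyridin-3-yl. Compound 4 carries a five-membered ring with one hydrogen-bond donor and two hydrogen-bond acceptors, so a move in the same direction as going from compound 3 back toward compound 2, and plausibly somewhat further, is expected.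

Compound 4 is therefore estimated at 1.7, with a likely range from 1.2 to 2.3, which means an expected step of a number 0.90 log units lower from compound 3 to compound 4 (beyond the scatter).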

Compound 4, distribution coefficient: 2
Estimate against measurement, compound 4: 0.30 log units below, within the range that was stated.
By their numbers in this assay, from the lowest: compounds 4 and 2 (each within the scatter of the next); then compound 3; then compound 1.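

At this position, on a carbonyl carbon whose other neighbour is an amide-type nitrogen in a ring, this assay separates 1H-1,2,3-triazol-4-yl from pyridin-3-yl, giving a number 0.60 log units lower from compound 3 to compound 4 (beyond the scatter). The new ring cannot be told apart from the other five-membered ring, 1H-pyrazol-4-yl, as the reading shows a number 0.10 log units lower from compound 2 to compound 4 (within the scatter), so among these three aromatic rings the two five-membered ones stand together and pyridin-3-yl stands apart from both. The step away from trifluoromethyl, a number 2.90 log units lower from compound 1 to compound 4 (beyond the scatter), is much larger than any step among the rings, so in this small set, replacing trifluoromethyl with any of the three rings moves the number far more than the choice of ring does.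

Nothing shown here explains why the numbers fall as they do. The compounds shown also leave open where other groups on this carbonyl carbon would fall, such as a plain phenyl ring with no ring nitrogen, a tetrazole, or a non-aromatic group such as a short amine-bearing chain, and so whether the closeness of the two five-membered rings extends beyond this pair.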